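The compounds below may be only part of what the source reports. "The series", "measured", "known", "first", "only" and "open" are said of these compounds alone.

The measured compounds and their values in a functional assay on T98G cells (Homo sapiens) for inhibition, read by MTT assay, with a stated time of 72 h (a higher number here means a weaker inhibitor, a lower number a stronger inhibitor), are these:

compound 1, `COc1ccccc1NC(=S)NC1CC(C)(C)Oc2ccc(Br)cc21`: 42000 nM
compound 2, `CC1(C)CC(NC(=O)Nc2ccccc2Cl)c2cc(F)ccc2O1`: 27000 nM
compound 3, `CC1(C)CC(NC(=O)Nc2ccccc2Cl)c2cc(Cl)ccc2O1`: 20000 nM

Compound 1 has the highest of the three numbers in this assay. Compound 2 lies within the scatter of it, while the gap to compound 3 is beyond the scatter. Going by the values given here, the only single-site step among the measured compounds is a 1.4-fold lower number from compound 2 to compound 3 (0.13 log units; within the scatter), which concerns a halogen on the shared core and not the thiourea substituent.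

Compound 4, `CC1(C)CC(NC(=S)Nc2ccc(C#N)cc2)c2cc(Br)ccc2O1`, differs from compound 1 in that (4-cyanophenyl in place of 2-methoxyphenyl on an amide-type nitrogen). Among the compounds with values here, no measured step touches this position, so there is nothing in these data to suggest a change beyond the scatter, and the expectation is built around the value of compound 1 with a wide range. The step from compound 1 to compound 4 is expected to be a 1.4-fold lower number from compound 1 to compound 4 (0.15 log units; within the scatter), and compound 4 is therefore estimated to give 30000 nM in this assay, between 9000 nM and 100000 nM.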

Compound 4, half-maximal inhibitory concentration: 24000 nM
Estimate against measurement, compound 4: 1.3-fold (0.10 log units) above, and the stated range covers the measured number.
By their numbers in this assay, from the lowest: compounds 3, 4, 2 and 1 (each within the scatter of the next, the first and the last beyond it).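

Replacing 2-methoxyphenyl with 4-cyanophenyl on the amide-type nitrogen gives a 1.8-fold lower number from compound 1 to compound 4 (0.24 log units; within the scatter) in this assay, the only step shown at this position. Two aryl groups of the same heavy-atom count, one carrying a methoxy group and the other a nitrile, are therefore not told apart by this read-out, and the exchange does not move the number beyond the scatter. Nothing available explains this result or links it to any property of either group.

The compounds shown leave open whether a different substituent on this nitrogen, such as a phenyl carrying an amine or a carboxylic acid, or a longer alkyl chain, would move the number beyond the scatter. Going by these compounds, it also remains open whether exchanging the thiocarbonyl for a carbonyl, with all else kept, would shift the number.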